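The source may report more compounds than this note shows. Statements on the series, on what has been measured and on what is new or still open speak of the compounds shown alone.

Measured so far:
compound 1 `CCC1(C)C(=O)N(c2ccccc2)c2ncccc21` with 36%
compound 2 `CCC1(CC)C(=O)N(c2ccccc2)c2ncccc21` with 13%
compound 3 `CC1(C)C(=O)N(c2cccc(Cl)c2)c2ncccc21` with 51%

Of the compounds shown here, three sharing one core have been tested in a functional assay on the whole organism (Pleural cavity) for inhibition, with Rattus norvegicus as the target, at a dose of 25 mg/kg; a higher number here means more inhibition at the dose given (going by the name of the read-out), a lower number less inhibition. Compound 1 gives 36%, which places it second of the three: compound 3 gives a higher number, and compound 2 gives a lower one, both gaps being beyond the usual scatter.

Within the data shown here, only one pair among the measured compounds differs in a single place. Between compound 1 and compound 2 a methyl replaces a hydrogen on a saturated chain carbon bound to a saturated ring carbon, and this assay falls a number 23 percentage points lower from compound 1 to compound 2 (beyond the scatter). Compound 3 differs from compound 1 in two places at once, so its higher number cannot be tied to either change alone.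

The unmeasured compound 4 `CC1C(=O)N(c2ccccc2)c2ncccc21` differs from compound 1 in one place: hydrogen in place of ethyl on a saturated ring carbon. The ethyl, a group of two carbon atoms, leaves, and a hydrogen enters on the saturated ring carbon of the five-membered non-aromatic ring. Among the measured compounds shown here, this is the reverse direction of the only measured step: there, adding carbon on that part of the molecule lowered the number. Less carbon at the same place may therefore raise it, though only one step supports this and its size need not carry over.

The expectation for compound 4 is a modest rise, a number 9 percentage points higher from compound 1 to compound 4 (within the scatter). Compound 4 is estimated at 45%, within a range from 25% to 65%.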

Compound 4, a percentage reported as inhibition, in the whole organism at one dose (the size of the read-out at that dose, not a potency): 29%
Estimate against measurement, compound 4: 16 percentage points above; the range from low to high includes it.
By their numbers in this assay, from the lowest: compound 2; then compounds 4 and 1 (each within the scatter of the next); then compound 3.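

Removing the ethyl from this saturated ring carbon, so that only a hydrogen and the methyl remain there, gives in this assay a number 7 percentage points lower from compound 1 to compound 4 (within the scatter) and so produces no change that can be told apart from the scatter. The earlier step at the same carbon, a number 23 percentage points lower from compound 1 to compound 2 (beyond the scatter), had suggested that the amount of carbon there might set the number, but the new result shows that this does not hold as a simple trend: enlarging the methyl to an ethyl on the compound that already carries an ethyl costs inhibition, while taking the ethyl away gains none. Nothing at hand explains why these two changes at one carbon behave so differently.

The compounds shown leave open how this carbon would respond to a longer chain such as propyl, or to a group of another kind such as an amine or a carboxylic acid. They also leave open how much of the number for compound 3 belongs to the chlorine on its phenyl group, since that compound differs from compound 1 in two places.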